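The source may hold more compounds than are shown below. What is called first, only, known or untested is meant among the compounds shown, and "the series" means these compounds.

Working notes on the series.

Going by the values given here, compound 2 `COc1cc(C#N)cc(-c2c(C)nn(-c3nc(-c4ccc(Cl)c(Cl)c4)c(SC(C)C)s3)c2C(=O)O)c1` stands lowest of the two numbers so far: in a functional assay on BJAB cells (Homo sapiens) for antiproliferative activity, with a stated time of 4 days (a lower number here means that less compound is needed, a higher number that more compound is needed for the effect), compound 2 gives 5200 nM, and its nearest neighbour, compound 1 `Cc1nn(-c2nc(-c3ccc(Cl)c(Cl)c3)c(SC(C)C)s2)c(C(=O)O)c1-c1cncnc1`, gives in this assay 22000 nM. Among the compounds with values here, the one step between measured compounds, a 4.2-fold lower number from compound 1 to compound 2 (0.63 log units; beyond the scatter), exchanges the whole aryl group on the shared core and says nothing about a single substituent on that aryl ring.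

Compound 3 `COc1cc(Cl)cc(-c2c(C)nn(-c3nc(-c4ccc(Cl)c(Cl)c4)c(SC(C)C)s3)c2C(=O)O)c1` is not yet measured. It differs from compound 2 by chloro in place of cyano on an aromatic carbon. Within the data shown here, no measured step in this assay tracks a cyano-to-chloro exchange, so there is no direct precedent; the step from compound 1 to compound 2 only shows that this aryl group matters, not which part of it. Without a bearing step, the expectation for compound 3 is a number close to that of compound 2, with no change beyond the scatter: an estimated step of a 1.0-fold lower number from compound 2 to compound 3 (0.02 log units; within the scatter). In this assay compound 3 is therefore expected at about 5000 nM, with a range from 1800 nM to 14000 nM.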

Compound 3, half-maximal effective concentration: 760 nM
Estimate against measurement, compound 3: 6.6-fold (0.82 log units) above, and the stated range ends above it.
By their numbers in this assay, from the lowest: compound 3; then compound 2; then compound 1.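

The step of a 6.8-fold lower number from compound 2 to compound 3 (0.84 log units; beyond the scatter) in this assay shows that this position on the aryl ring matters in its own right: with the methoxy group and the rest of the structure held fixed, chloro in place of cyano alone moves the number beyond the scatter. The earlier exchange of the whole aryl group could not separate a single substituent in this way, whereas the step of a 29-fold lower number from compound 1 to compound 3 (1.46 log units; beyond the scatter), now large, shows how much the full replacement of pyrimidin-5-yl by 3-chloro-5-methoxyphenyl can change the number. No accompanying measurement bears on this result, and the difference between chloro and cyano at this position remains unexplained.

The compounds shown give only two substituents at this position, so it remains open whether bromo, methyl, trifluoromethyl or an amine would continue the step from cyano to chloro or reverse it. The methoxy group is present in both compound 2 and compound 3, leaving open whether chloro would give a similar step with hydroxy or ethoxy in its place.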